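Varying the aryl hydrazone group in a triazole series

The source may report more compounds than this note shows. Statements on the series, on what has been measured and on what is new or still open speak of the compounds shown alone.

Compound 1 `CN(C)CCn1cnnc1-c1cc(Oc2ccc(NC(=O)N/N=C/c3ccc(O)c(O)c3)cc2F)ccn1` gives 1890 nM in a functional assay on HT-29 cells (Homo sapiens) for cytotoxicity, read by MTT assay, with a stated time of 72 h; on this read-out lower numbers stand for stronger inhibition and higher numbers for weaker inhibition.
Compound 2 `CN(C)CCn1cnnc1-c1cc(Oc2ccc(NC(=O)N/N=C/c3cc(C(C)(C)C)cc(C(C)(C)C)c3O)cc2F)ccn1` gives 680 nM in this assay.
Compound 3 `CN(C)CCn1cnnc1-c1cc(Oc2ccc(NC(=O)N/N=C/c3cc(Br)c(O)c(Br)c3)cc2F)ccn1` gives 2670 nM in this assay.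

Within this small set, compound 3 carries the highest number in this assay. Its nearest neighbour is compound 1, and the step of a 1.4-fold higher number from compound 1 to compound 3 (0.15 log units; within the scatter) lies within the scatter, so the two cannot be ordered. The only gap beyond the scatter separates compound 3 from compound 2, which sits at the lower end of the three values.

Compound 4 `COc1ccc(/C=N/NC(=O)Nc2ccc(Oc3ccnc(-c4nncn4CCN(C)C)c3)c(F)c2)cc1O` has not yet been measured in this assay. It differs from compound 3 in one place: 3-hydroxy-4-methoxyphenyl in place of 3,5-dibromo-4-hydroxyphenyl on a carbon with a double bond to nitrogen

Among the compounds with values here, the one measured step that bears on this change is the exchange of one aryl group for another at the same position, from compound 1 to compound 3, and that step was a 1.4-fold higher number from compound 1 to compound 3 (0.15 log units; within the scatter). Within the data shown here, nothing among the measured compounds points to a larger shift for an exchange of this kind, so the expectation is a step from compound 3 to compound 4 of no more than the scatter, a 1.5-fold lower number from compound 3 to compound 4 (0.17 log units; within the scatter), and compound 4 is therefore estimated at 1800 nM in this assay, within a range of 900 nM to 3600 nM.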

Compound 4, half-maximal inhibitory concentration: 960 nM
Compound 4: middle estimate off by 1.9-fold (0.27 log units), on the high side, and the stated range covers the measured number.
By their numbers in this assay, from the lowest: compounds 2, 4, 1 and 3 (each within the scatter of the next, the first and the last beyond it).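

With the same count of heavy atoms on each side, the exchange of 3,5-dibromo-4-hydroxyphenyl for 3-hydroxy-4-methoxyphenyl on the carbon with a double bond to nitrogen gives a 2.8-fold lower number from compound 3 to compound 4 (0.44 log units; beyond the scatter) in this assay and so moves the number by more than the scatter. The earlier exchange at this place had stayed within the scatter, so only now is there a measured sign that the aryl group here can change the read-out, and heavy-atom count alone does not account for that change. The other new step, with methyl in place of hydrogen on an oxygen on an aromatic ring, is a 2.0-fold lower number from compound 1 to compound 4 (0.29 log units; within the scatter) and stays within the scatter, so compound 1 and compound 4 cannot be ordered and this single change has no readable effect here.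

Nothing measured on these groups gives a reason for the step from compound 3 to compound 4. The compounds shown leave open whether the loss of the two bromine atoms or the entry of the 3-hydroxy-4-methoxyphenyl group sets the size of that step, and how an aryl group carrying an amine or a carboxylic acid would read in this place.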